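Methyl for methoxy on two ester-bearing naphthalene-type cores

This account rests on a few compounds, and the source may have more. Where it says the series, first, only, none or still open, it means among the compounds named here.

Measured compounds and their values:
compound 1, `COc1c(OC)c(OC(C)=O)c2c(OC)cccc2c1OC(C)=O`, 2.43
compound 2, `COc1c(OC)c(OC(=O)C(C)(C)C)c2c(OC)cccc2c1OC(=O)C(C)(C)C`, 5.6
compound 3, `COc1c(OC)c(OC(C)=O)c2c(C)cccc2c1OC(C)=O`, 2.8

Of the compounds shown here, three have been measured in a physicochemical assay for lipophilicity; on this read-out higher numbers stand for higher lipophilicity and lower numbers for lower lipophilicity. Compound 1 gives 2.43, and compound 3 gives 2.8. The two differ in one place:

methyl in place of methoxy on an aromatic carbon

That change made a step in this assay: a number 0.37 log units higher from compound 1 to compound 3 (beyond the scatter).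

Compound 2 carries the highest of the three numbers, at 5.6, which lies well above compound 3 and further still above compound 1. The difference between the core of compound 2 and the core of compound 1 is not broken down here.

The fourth compound, compound 4, `COc1c(OC)c(OC(=O)C(C)(C)C)c2c(C)cccc2c1OC(=O)C(C)(C)C`, has not yet been measured. It stands to compound 2 exactly as compound 3 stands to compound 1:

methyl in place of methoxy on an aromatic carbon

Since the two place descriptions agree word for word, this is the same change. Because a number 0.37 log units higher from compound 1 to compound 3 (beyond the scatter), a step of similar size is expected here, so the expected step is a number 0.37 log units higher from compound 2 to compound 4 (beyond the scatter). For compound 4 the estimate in this assay is 5.97, expected to fall between 5.5 and 6.4.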

Compound 4, partition coefficient: 6.1
The estimate for compound 4 lay 0.13 log units below the measured number; low and high end bracket the measured number.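

In this assay methyl in place of methoxy on an aromatic carbon moved the number the same way on both cores, with a number 0.37 log units higher from compound 1 to compound 3 (beyond the scatter) on the first core and a number 0.50 log units higher from compound 2 to compound 4 (beyond the scatter) on the second, so the direction of the step carried over from one core to the other in this series. For the compounds shown here, this rests on only two matched pairs, both beyond the scatter, and it does not show that the step would keep its direction or its size on any core outside these two. Nothing given here bears on why the number moves on either core.

The compounds shown leave open how other groups in the same place would behave, such as an amine, a carboxylic acid or a longer alkyl chain such as butyl in place of the methoxy. They also leave open what methyl would do in place of either of the other two methoxy groups on the shared core.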